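Swapping isopropyl for propyl on a weak growth inhibitor

The compounds below may be only part of what the source reports. "The series", "measured", "known", "first", "only" and "open" are said of these compounds alone.

- compound 1 `CCC1C(=O)N(C)c2cnc(-n3ccc4cc(C(=O)NC(C)C)ccc43)nc2N1c1ccn(C)n1`: 12200 nM
- compound 2 `CCCCNS(=O)(=O)c1ccc(Nc2ncc3c(n2)N(C2CCCC2)[C@H](CC)C(=O)N3C)cc1`: 1610 nM
- compound 3 `CC[C@@H]1C(=O)N(C)c2cnc(Nc3ccc(S(=O)(=O)NCCCO)cc3)nc2N1C1CCCC1`: 2140 nM

In a functional assay on NCI-H1975 cells (Homo sapiens) for antiproliferative activity, read by CCK-8 assay, with a stated time of 72 h (a higher number here means a weaker inhibitor of growth, a lower number a stronger inhibitor of growth), compound 1 gives 12200 nM, the highest of the three numbers, and both other compounds lie clearly lower. Compound 4 `CCCNC(=O)c1ccc2c(ccn2-c2ncc3c(n2)N(c2ccn(C)n2)C(CC)C(=O)N3C)c1` keeps everything in compound 1 except one group: propyl in place of isopropyl on an amide-type nitrogen. Among the compounds with values here, no measured pair makes this same exchange. Within the data shown here, the one measured step, a 1.3-fold higher number from compound 2 to compound 3 (0.12 log units; within the scatter), bears on it only loosely, since it alters the end of a sulfonamide chain and not an amide-type nitrogen. That step is small, and it offers the only hint that a modest edit to a chain may leave the number in this assay little changed. No step beyond the scatter is therefore expected, and the data suggest no direction. The expected change is a 1.1-fold lower number from compound 1 to compound 4 (0.04 log units; within the scatter). Compound 4 is estimated at 11000 nM, with an expected range of 4500 nM to 26000 nM.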

Compound 4, concentration for 50% growth inhibition: 11000 nM
For compound 4 middle estimate and measured number coincide at the digits printed; low and high end bracket the measured number.
By their numbers in this assay, from the lowest: compounds 2 and 3 (each within the scatter of the next); then compounds 4 and 1 (each within the scatter of the next).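

In this assay, the exchange of isopropyl for propyl on the amide-type nitrogen gives a 1.1-fold lower number from compound 1 to compound 4 (0.04 log units; within the scatter) and so stays within the scatter. Within the data shown here, this is the first direct reading at this position, as the earlier step concerned only the end of a sulfonamide chain, and it shows that the assay does not separate these two groups of the same size on the shared core. Nothing available explains why the number holds.

The compounds shown leave open whether a clearly different group on this nitrogen, such as a longer chain, a chain ending in an amine or one ending in a carboxylic acid, would shift the number beyond the scatter. They also leave open whether the same exchange would behave alike on another core.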